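Removing the benzyl ether from compound 3

A few compounds are considered here, and "the series" means these few. Any claim that something is new, unique, unknown or untested is made for them only; others in the source may bear on it.

Compound 3 `CCCCCCCCCCCCCCC(COCc1ccccc1)NC(=O)CCCC(=O)OC` gives 2.5% in an ADME assay on cells (Splenocyte, Mus musculus, strain BALB/c) for cytotoxicity, read by MTT assay, tested at 10 ug/mL; a lower number here means a weaker effect, a higher number a stronger effect of the compound at the concentration tested. Compound 2 `CCCCCCCCCCCCCCC(N)COCc1ccccc1` gives 12.2%, and the step of a number 9.7 percentage points lower from compound 2 to compound 3 (within the scatter) lies within the scatter, so the two cannot be ranked. Compound 1 `CCCCCCCCCCCCCCC(N)CO` gives 20.2%, and the gap from compound 1 to compound 3 is the only one in the set beyond the scatter. Compound 4 `CCCCCCCCCCCCCCC(CO)NC(=O)CCCC(=O)OC` differs from compound 3 in one place: hydrogen in place of benzyl on an oxygen on a saturated carbon. Within the data shown here, the only measured step that bears on this is the reverse change, a number 8 percentage points lower from compound 1 to compound 2 (within the scatter), within the scatter. Undoing it is expected to give at most a small rise, not beyond the scatter, so the expected step is a number 5.5 percentage points higher from compound 3 to compound 4 (within the scatter). Compound 4 is estimated at 8%, within 0% to 20%.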

Compound 4, a percentage reported as activity, at one concentration (the size of the read-out at that concentration, not a potency): 18.9%
Compound 4: the middle estimate sits 10.9 percentage points below what was measured; the range from low to high includes it.
By their numbers in this assay, from the lowest: compounds 3, 2, 4 and 1 (each within the scatter of the next, the first and the last beyond it).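

In this assay, among these compounds, taking the benzyl off the oxygen on the acylated core gives a number 16.4 percentage points higher from compound 3 to compound 4 (beyond the scatter), the first single change to pass the scatter. With the hydroxy group free, (3-(methoxycarbonyl)propyl)carbonyl on the amine nitrogen gives a number 1.3 percentage points lower from compound 1 to compound 4 (within the scatter), so this acyl group alone produces no readable change. The benzyl change cannot be said to differ between the two cores: the same change on two cores in this assay, a number 8 percentage points lower (within the scatter) from compound 1 to compound 2 and a number 16.4 percentage points lower (beyond the scatter) from compound 4 to compound 3, 8.4 percentage points apart, within the scatter of two such steps

Open, as far as these compounds go, is whether a methyl ether on this oxygen behaves like benzyl or like hydrogen. Also open, from the compounds shown here alone, is what a carboxylic acid in place of the methyl ester, or a shorter chain, would do to the read-out.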